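A few compounds are considered here, and "the series" means these few. Any claim that something is new, unique, unknown or untested is made for them only; others in the source may bear on it.

Compound 3 `C=CCn1c(=O)/c(=C\c2ccccc2C(F)(F)F)[nH]c(=O)/c1=C\c1ccccc1OC` is measured in a functional assay on NCI-H1975 cells (Homo sapiens) for cytotoxicity, read by CCK-8 assay, with a stated time of 72 h (on this read-out lower numbers stand for stronger inhibition and higher numbers for weaker inhibition), where compound 3 gives 14500 nM. Among the compounds with a reported number it holds the lowest value, its nearest neighbour being compound 1 `C=CCn1c(=O)/c(=C\c2cccc(F)c2)[nH]c(=O)/c1=C\c1ccccc1OC`, which in this assay gives 25600 nM; the step of a 1.8-fold lower number from compound 1 to compound 3 (0.25 log units; within the scatter) lies within the scatter, so the two cannot be ordered. Compound 2 `C=CCn1c(=O)/c(=C\c2cc(Br)ccc2F)[nH]c(=O)/c1=C\c1ccccc1OC`, which also carries a bromine and a fluorine on the phenyl at that chain carbon, in this assay is reported as "not active" (no number reported), with no number given.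

Compound 4 `C=CCn1c(=O)/c(=C\c2ccc(F)c(Br)c2)[nH]c(=O)/c1=C\c1ccccc1OC` differs from compound 3 by 3-bromo-4-fluorophenyl in place of 2-(trifluoromethyl)phenyl on a double-bonded chain carbon bound to an aromatic carbon. No measured step carries exactly this change; the one step shown, from compound 1 to compound 3, was within the scatter, while compound 2, the only other bromine-and-fluorine bearing entry, returned no number at all. On that basis a weakening, or a result without a number, is expected for compound 4, an estimated step of a 2.1-fold higher number from compound 3 to compound 4 (0.32 log units; beyond the scatter). Compound 4 is therefore estimated at 30000 nM, within a range from 12000 nM to 80000 nM.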

Compound 4, half-maximal inhibitory concentration: "not active" (no number reported)
No number was reported for compound 4, so the estimate cannot be set against anything.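

Going by these compounds alone, compound 4 is reported without a number, so no step from compound 3 to it can be read. The compounds shown leave open how far 3-bromo-4-fluorophenyl and 2-(trifluoromethyl)phenyl differ in cytotoxicity on these cells. No evidence shown bears on this result.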